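Exchanging One Group on a Shared Core

A few compounds are considered here, and "the series" means these few. Any claim that something is new, unique, unknown or untested is made for them only; others in the source may bear on it.

Of the compounds shown here, two have been measured so far. In a functional assay on HCT-116 cells (Homo sapiens) for cytotoxicity, read by MTT assay, with a stated time of 72 h (on this read-out lower numbers stand for stronger inhibition and higher numbers for weaker inhibition), compound 1 (`Nc1cccc(Nc2nc3ccccc3nc2S(=O)(=O)c2ccc(Br)cc2)c1`) gives 3280 nM and compound 2 (`COc1ccc(Nc2nc3ccccc3nc2S(=O)(=O)c2ccc(F)cc2)cc1`) gives 3010 nM as its value. These two numbers lie within the usual scatter of each other, so compound 2 cannot be told apart from compound 1 on this measure. The next molecule is compound 3 (`Nc1cccc(Nc2nc3ccccc3nc2S(=O)(=O)c2ccc(F)cc2)c1`), which differs from compound 2 in one place: 3-aminophenyl stands in place of 4-methoxyphenyl on a nitrogen on an aromatic ring (3-aminophenyl in place of 4-methoxyphenyl on a nitrogen on an aromatic ring). The 3-aminophenyl group already occurs in compound 1 at 3280 nM in this test, a number within the scatter of compound 2, so no clear shift in either direction is expected. The expected change is a 1.0-fold lower number from compound 2 to compound 3 (0.00 log units; within the scatter) and stays within the scatter. For compound 3 the estimated value is 3000 nM with an expected range from 1200 nM to 7500 nM in repeated measurements.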

Compound 3, half-maximal inhibitory concentration: 6790 nM
Compound 3: middle estimate off by 2.3-fold (0.35 log units), on the low side; low and high end bracket the measured number.
By their numbers in this assay, from the lowest: compounds 2 and 1 (each within the scatter of the next); then compound 3.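

With the fluoro group held fixed, the group on the nitrogen matters in this assay: 3-aminophenyl in place of 4-methoxyphenyl gives weaker inhibition (a 2.3-fold higher number from compound 2 to compound 3 (0.35 log units; beyond the scatter)). The halogen matters as well, since with 3-aminophenyl held fixed, fluoro in place of bromo on an aromatic carbon also weakens inhibition (a 2.1-fold higher number from compound 1 to compound 3 (0.32 log units; beyond the scatter)). Both steps are modest, yet each lies beyond the usual scatter, so these two single exchanges on the shared core can be read as real shifts. Nothing at hand explains either shift.

From the compounds shown here alone, whether the halogen step would stay the same with 4-methoxyphenyl on the nitrogen remains open. So does the outcome with a chloro group in place of the fluoro, or with a carboxylic acid in place of the amine on the phenyl ring.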